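The compounds below may be only part of what the source reports. "The series", "measured", "known", "first", "only" and "open" are said of these compounds alone.

Measured in an ADME assay on BJ cells (Homo sapiens) for cytotoxicity, read by luminescence, with a stated time of 72 h (a higher number here means that more compound is needed for the effect, a lower number that less compound is needed), each value being a limit:

Compound 1 `CCOC(=O)c1c(-c2cccc(C)c2)[nH]c2cc(OC)ccc2c1=O` gives > 21500 nM as a limit
Compound 2 `CCCOc1cccc(-c2[nH]c3cc(OC)ccc3c(=O)c2C(=O)OCC)c1` gives > 21500 nM as a limit
Compound 3 `CCOC(=O)c1c(-c2cccc(F)c2)[nH]c2cc(OC)ccc2c1=O` gives > 21500 nM as a limit

Compound 3 therefore offers no number, and the limit of > 21500 nM in this assay, at which 3 of the 3 values shown sit, describes the whole set. Compound 4 `CCOC(=O)c1c(-c2cccc(Br)c2)[nH]c2cc(OC)ccc2c1=O` has bromo in place of fluoro on an aromatic carbon, meta to a large group (bromo in place of fluoro on an aromatic carbon). The measured changes on this ring are a step that the two limits leave unreadable from compound 1 to compound 3, a step that the two limits leave unreadable from compound 2 to compound 3 and a step that the two limits leave unreadable from compound 1 to compound 2, and none yields a size. Since compound 3 sits at the limit of > 21500 nM in this assay, no step beyond the scatter is expected, in either direction. The expected outcome is a number no higher from compound 3 to compound 4 (the limit leaves the size open) by this estimate. Compound 4 is estimated at 21500 nM, with an expected range from 11000 nM to 40000 nM, and it will probably read as a limit again.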

Compound 4, half-maximal effective concentration: > 21500 nM
Compound 4 was reported as a limit; the forecaster's own chance of this, stated with the estimate: 80%; the middle value lies on the limit itself.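

In this assay no step can be read between compound 4 and compound 1, compound 2 or compound 3, as all are limits: the limit of > 21500 nM in this assay, at which 4 of the 4 values shown sit.

The compounds shown leave open what concentration any of them needs for the effect, and whether methyl, propoxy, fluoro and bromo differ at all.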